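This account rests on a few compounds, and the source may have more. Where it says the series, first, only, none or still open, it means among the compounds named here.

Compounds measured so far in an ADME assay on HEK293 cells (Homo sapiens) for cytotoxicity, read by resazurin assay, with a stated time of 48 h; on this read-out lower numbers stand for higher toxicity in this test and higher numbers for lower toxicity in this test:

compound 1, `O=S(=O)(Nc1ccc(-c2nc3ccccc3o2)cc1)c1ccc(Cl)s1`, gives > 100000 nM
compound 2, `O=S(=O)(Nc1ccc(-c2nc3ccccc3o2)cc1)c1ccc(F)c(C(F)(F)F)c1`, gives 82000 nM
compound 3, `O=[N+]([O-])c1cc(S(=O)(=O)Nc2ccc(-c3nc4ccccc4o3)cc2)ccc1Cl`, gives 85000 nM

These three compounds share one core and differ only in the group attached to the sulfonyl sulfur. For compound 1 the reading in this assay is a limit of the test, not a number: the cells tolerated it up to the highest concentration tried, so it sits at the limit of > 100000 nM in this assay, at which 1 of the 3 values shown sits. Compound 2 and compound 3 each give a number, and the two numbers are within the usual scatter of each other, so neither can be called more or less toxic than the other. Taken together, all three compounds cause little harm to these cells.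

Compound 4, `COc1ccc(Cl)cc1S(=O)(=O)Nc1ccc(-c2nc3ccccc3o2)cc1`, has not yet been measured. It differs from compound 1 by a single change: 5-chloro-2-methoxyphenyl in place of 5-chlorothiophen-2-yl on a sulfonyl sulfur. Among the compounds with values here, no measured pair in this set tracks exactly this kind of change, so the step has to be judged from the three values alone, and all of them cluster at the weak end of this assay. The expectation is therefore a step of no size beyond the scatter, a number no higher from compound 1 to compound 4 (the limit leaves the size open), and compound 4 is estimated at 100000 nM, with a likely range from 50000 nM to 200000 nM.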

Compound 4, half-maximal cytotoxic concentration: 75000 nM
Compound 4: middle estimate off by 1.3-fold (0.12 log units), on the high side; measured number inside the range.
By their numbers in this assay, from the lowest: compounds 4, 2 and 3 (each within the scatter of the next). At a limit, above all of these: compound 1.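

In this assay, placing 5-chloro-2-methoxyphenyl in place of 5-chlorothiophen-2-yl on a sulfonyl sulfur gives an at least 1.3-fold lower number from compound 1 to compound 4 (0.12 log units; that floor lies within the scatter). This is the first pair shown that differs in one place, and it shows that a six-membered aromatic ring of carbon only, with more heavy atoms, can replace a five-membered aromatic ring with a hetero atom here without a step that can be called real, since the smallest possible step lies within the scatter. Compound 1 stands at a limit, not at a number, and so the true size of the step stays open: the limit of > 100000 nM in this assay, at which 1 of the 4 values shown sits.

Also open, going by these compounds, is how much of any step belongs to the change of ring and how much to the methoxy group, since the two enter together. Every compound shown also carries an aromatic ring on the sulfonyl sulfur, which leaves open what a plain alkyl chain there, or a ring bearing an amine or a carboxylic acid, would do to these cells.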